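A few compounds are considered here, and "the series" means these few. Any claim that something is new, unique, unknown or untested is made for them only; others in the source may bear on it.

Of the compounds shown here, three built on the same core have been measured. Compound 1 `CCCCCC(=O)OC[C@H]1O[C@@H](n2ccc(N)nc2=O)[C@@H](O)[C@@H]1OC(=O)CCCCC` carries two chains, each attached through a carbonyl, and in a functional assay on HeLa cells (Homo sapiens) for cytotoxicity, read by cell counting, with a stated time of 48 h (on this read-out higher numbers stand for an effect only at larger amounts of compound and lower numbers for an effect already at smaller amounts), compound 1 gives 0.07 ug/mL. Compound 2 `CCCC(=O)O[C@H]1[C@H](O)[C@H](n2ccc(N)nc2=O)O[C@@H]1CO` carries a single short chain, and in this assay compound 2 gives 0.11 ug/mL. Compound 3 `CCCCCCCCCCCC(=O)O[C@H]1[C@H](O)[C@H](n2ccc(N)nc2=O)O[C@@H]1CO` carries a single longer chain, and in this assay compound 3 gives 0.08 ug/mL. Among these three numbers compound 3 stands second highest, yet its distance to each of the other two is within the scatter of repeated measurements, so the three compounds cannot be told apart on this read-out.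

The next compound, compound 4 `CCCCCCCCCCCCCCCCCC(=O)O[C@H]1[C@H](O)[C@H](n2ccc(N)nc2=O)O[C@@H]1CO`, differs from compound 3 in one place: hexyl in place of hydrogen on a saturated chain carbon, ten or more bonds along the chain from a carbonyl carbon. Within the data shown here, the one measured step that bears on this change is a 1.4-fold lower number from compound 2 to compound 3 (0.14 log units; within the scatter). That step also added carbons to the chain, and it produced nothing beyond the scatter. The expectation is therefore that a further lengthening of the same chain likewise moves the number no further than the scatter, in either direction. On that basis compound 4 is expected to give 0.09 ug/mL, with a range from 0.03 ug/mL to 0.3 ug/mL, which corresponds to an expected step of a 1.1-fold higher number from compound 3 to compound 4 (0.05 log units; within the scatter).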

Compound 4, concentration for half-maximal effect: 0.13 ug/mL
Compound 4: middle estimate off by 1.4-fold (0.16 log units), on the low side; measured number inside the range.
By their numbers in this assay, from the lowest: compounds 1, 3, 2 and 4 (each within the scatter of the next).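

In this assay, hexyl in place of hydrogen on a saturated chain carbon, ten or more bonds along the chain from a carbonyl carbon, gives a 1.6-fold higher number from compound 3 to compound 4 (0.21 log units; within the scatter), and this step lies within the scatter of repeated measurements. The earlier step, a 1.4-fold lower number from compound 2 to compound 3 (0.14 log units; within the scatter), also lies within the scatter, so neither lengthening of the single chain, the second now reaching far out along it, can be told apart from repeat-to-repeat variation, and compounds 2, 3 and 4 show no measurable dependence on chain length at this position. No separate measurement is available to explain this result.

Still open, from the compounds shown here alone, is whether a longer chain than that of compound 4, or an amine or a carboxylic acid in the place of its hexyl, would move the number beyond the scatter. Going by these compounds, compound 1 differs from compounds 2, 3 and 4 in more than one place, so what its second chain contributes also remains open.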